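A few compounds are considered here, and "the series" means these few. Any claim that something is new, unique, unknown or untested is made for them only; others in the source may bear on it.

Three compounds have been measured in a functional assay on HL-60 cells (Homo sapiens) for antiproliferative activity, with a stated time of 24 h; a lower number here means a stronger inhibitor, a higher number a weaker inhibitor:

compound 1, `NC(=O)c1c(NC(=O)c2ccc(C(F)(F)F)cc2)sc2c1CCN(Cc1ccc(Cl)cc1Cl)C2`, 14900 nM
compound 2, `Cc1ccc(C(=O)Nc2sc3c(c2C(N)=O)CCN(Cc2ccc(Cl)cc2Cl)C3)cc1`, 19900 nM
compound 3, `NC(=O)c1c(NC(=O)c2ccccc2C(F)(F)F)sc2c1CCN(C(=S)Nc1ccccc1Br)C2`, 25500 nM

Compound 1 and compound 2 share a core and differ in a single place: methyl in place of trifluoromethyl on an aromatic carbon. In this assay this change made a step of a 1.3-fold higher number from compound 1 to compound 2 (0.13 log units; within the scatter). Compound 3 carries a core that differs from that of compound 1 in more than one place, and the difference between the two cores is not broken down here; its value in this assay lies within the scatter of both compound 1 and compound 2, so the three measured values show no separation from one another.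

Compound 4, `Cc1ccccc1C(=O)Nc1sc2c(c1C(N)=O)CCN(C(=S)Nc1ccccc1Br)C2`, has not yet been measured in this assay. It differs from compound 3 in one place: methyl in place of trifluoromethyl on an aromatic carbon. Among the measured compounds shown here, this is the same kind of change as the one from compound 1 to compound 2, but not the same change, since in compound 4 the methyl sits ortho to a large group, whereas in compound 2 it sits para to a large group. For the measured compounds named here, the expected step from compound 3 to compound 4 in this assay is a 1.2-fold higher number from compound 3 to compound 4 (0.07 log units; within the scatter), placed beside the earlier step of a 1.3-fold higher number from compound 1 to compound 2 (0.13 log units; within the scatter); this expectation rests on that earlier step alone, as it is the only measured instance of the change. The value of compound 4 in this assay is therefore estimated at 30000 nM, with a range from 12000 nM to 70000 nM.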

Compound 4, half-maximal inhibitory concentration: 45200 nM
The estimate for compound 4 lay 1.5-fold (0.18 log units) below the measured number; the measured number falls inside the stated range.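

In this assay, among the compounds shown here, putting methyl in place of trifluoromethyl on the core of compound 3 gave a 1.8-fold higher number from compound 3 to compound 4 (0.25 log units; within the scatter), so the change, here 2-(trifluoromethyl)phenyl to 2-methylphenyl, produced no step that stands clear of the usual scatter. Set beside the earlier instance, the two steps do not differ, and the change carried from one core to the other without any measurable difference: the same change on two cores in this assay, a 1.3-fold higher number (0.13 log units; within the scatter) from compound 1 to compound 2 and a 1.8-fold higher number (0.25 log units; within the scatter) from compound 3 to compound 4, 1.3-fold (0.12 log units) apart, within the scatter of two such steps This does not show that the change has a real effect on either core, since both steps are within the scatter, nor does it establish a rule for the series, since it rests on two pairs only, and those pairs carry the change at different places on the aromatic ring.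

The compounds shown leave open whether another group on that aromatic carbon, such as methoxy, an amine or a carboxylic acid, would give a step beyond the scatter in this assay. They also leave open whether the exchange of trifluoromethyl for methyl would stay this small on a third core, for instance one carrying a longer chain on the ring nitrogen.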